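From Dimethoxyphenyl to Acetylphenyl in Compound 3

This account rests on a few compounds, and the source may have more. Where it says the series, first, only, none or still open, it means among the compounds named here.

In a functional assay on SK-OV-3 cells (Homo sapiens) for antiproliferative activity, read by MTT assay, with a stated time of 72 h (a higher number here means a weaker inhibitor, a lower number a stronger inhibitor), compound 3 (`COc1cc(OC)cc(-c2cccc(NC(=O)CCc3cccc4c3COB4O)c2)c1`) gives 88000 nM and compound 2 (`COc1cccc(-c2cccc(NC(=O)CCc3cccc4c3COB4O)c2)c1`) gives 78000 nM, values within the scatter of each other. Compound 1 (`CC(=O)c1ccc(-c2cccc(NC(=O)CCc3ccc4c(c3)B(O)OC4)c2)cc1`), which also carries 4-acetylphenyl on its own core, gives only a limit of the assay, > 100000 nM.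

Compound 4 (`CC(=O)c1ccc(-c2cccc(NC(=O)CCc3cccc4c3COB4O)c2)cc1`) has 4-acetylphenyl in place of 3,5-dimethoxyphenyl on an aromatic carbon. For the measured compounds named here, the one measured step on this ring, a 1.1-fold higher number from compound 2 to compound 3 (0.05 log units; within the scatter), adds a methoxy group and stays within the scatter, so no change beyond the scatter is expected here.

The estimated step is a 1.0-fold higher number from compound 3 to compound 4 (0.01 log units; within the scatter).

For compound 4 the expected value is 90000 nM, with an estimated range of 50000 nM to 160000 nM.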

Compound 4, half-maximal inhibitory concentration: 57000 nM
Compound 4: the middle estimate sits 1.6-fold (0.20 log units) above what was measured, and the stated range covers the measured number.
By their numbers in this assay, from the lowest: compounds 4, 2 and 3 (each within the scatter of the next). At a limit, above all of these: compound 1.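

Swapping the aryl group for 4-acetylphenyl gives a 1.5-fold lower number from compound 3 to compound 4 (0.19 log units; within the scatter), and a 1.4-fold lower number from compound 2 to compound 4 (0.14 log units; within the scatter), so a ketone-bearing ring at this position cannot be told apart from the methoxy-bearing rings. All three compounds on this core remain weak together. The change of core gives an at least 1.7-fold lower number from compound 1 to compound 4 (0.24 log units; that floor lies within the scatter), which is only a floor and shows no clear effect of the core: the limit of > 100000 nM in this assay, at which 1 of the 4 values shown sits.

Still open, as far as these compounds go, is whether any group on this ring can move the number beyond the scatter. An amine or a carboxylic acid in place of the acetyl group, or a longer chain before the amide, would test this.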